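Aryl variation on the chain carbon, histamine antagonism on ileum

This account rests on a few compounds, and the source may have more. Where it says the series, first, only, none or still open, it means among the compounds named here.

Measured compounds:
Compound 1, `N=C(NCCCc1c[nH]cn1)NCCC(c1cccc(C(F)(F)F)c1)c1ccccn1`: in a functional assay on ileum for antagonist activity at histamine H1 receptor (Cavia porcellus) (on this read-out higher numbers stand for weaker binding and lower numbers for tighter binding), compound 1 gives 525 nM.
Compound 2, `N=C(NCCCc1c[nH]cn1)NCCC(c1cc(F)cc(F)c1)c1ccccn1`: in this assay compound 2 gives 275 nM.

Compound 2 carries the lower of the two numbers, but the step of a 1.9-fold lower number from compound 1 to compound 2 (0.28 log units; within the scatter) is within the scatter, so compounds 1 and 2 are not separated by this assay. Both share the same core; they differ only in the aryl group on the saturated chain carbon bound to an aromatic carbon and a saturated chain carbon.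

Compound 3, `N=C(NCCCc1c[nH]cn1)NCCC(c1ccc(Cl)c(Cl)c1)c1ccccn1`, is the next change at that same position: 3,4-dichlorophenyl in place of 3,5-difluorophenyl on a saturated chain carbon bound to an aromatic carbon and a saturated chain carbon. Going by the values given here, the only measured step at this position is a 1.9-fold lower number from compound 1 to compound 2 (0.28 log units; within the scatter), and it did not move the number beyond the scatter. Among the compounds with values here, no measured step speaks to chlorine in place of fluorine, or to 3,4-dichlorophenyl in place of 3,5-difluorophenyl. On this basis the expected step is a 1.1-fold higher number from compound 2 to compound 3 (0.04 log units; within the scatter), that is, no change beyond the scatter. For compound 3 the number in this assay is estimated at 300 nM, with a range from 100 nM to 900 nM.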

Compound 3, dissociation constant: 79.4 nM
Beside the measured number, compound 3's estimate is 3.8-fold (0.58 log units) above it; measured number below the stated range.
By their numbers in this assay, from the lowest: compound 3; then compounds 2 and 1 (each within the scatter of the next).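

In this assay, going by these compounds alone, the aryl group on the saturated chain carbon bound to an aromatic carbon and a saturated chain carbon can shift the number beyond the scatter, which the earlier pair could not show: its only step was a 1.9-fold lower number from compound 1 to compound 2 (0.28 log units; within the scatter). Replacing 3,5-difluorophenyl with 3,4-dichlorophenyl gives a 3.5-fold lower number from compound 2 to compound 3 (0.54 log units; beyond the scatter), and replacing 3-(trifluoromethyl)phenyl with the same group gives a 6.6-fold lower number from compound 1 to compound 3 (0.82 log units; beyond the scatter), so compound 3 is separated from both neighbours while those two remain unseparated from each other. No supporting measurement accounts for this difference.

The change from 3,5-difluorophenyl to 3,4-dichlorophenyl alters the halogen and its placement on the ring together, so these compounds cannot assign the step to chlorine or to the substitution pattern. Also open, from the compounds shown here alone, is how an unsubstituted phenyl, or an aryl group carrying an amine or a carboxylic acid, would read at this carbon, and whether the step seen with 3,4-dichlorophenyl would persist with a longer chain in the shared core.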